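Acetylating a free hydroxyl in a diterpenoid lactone series

This account rests on a few compounds, and the source may have more. Where it says the series, first, only, none or still open, it means among the compounds named here.

Of the compounds shown here, three of a shared core have been tested in a functional assay on P388 cells (Mus musculus) for cytotoxicity, read by sulforhodamine B assay; a lower number here means that less compound is needed, a higher number that more compound is needed for the effect. Compound 1, with the structure `C=C1CC[C@@H]2[C@](C)(CO[Si](C)(C)C(C)(C)C)[C@H](OC(C)=O)CC[C@@]2(C)[C@@H]1C/C=C1/C(=O)OC[C@H]1OC(C)=O`, gives 0.34 uM. Compound 3, with the structure `C=C1CC[C@@H]2[C@](C)(CO[Si](C)(C)C(C)(C)C)[C@H](OC(C)=O)CC[C@@]2(C)[C@@H]1C/C=C1/C(=O)OC[C@H]1O`, gives 1.71 uM. Compound 2, with the structure `C=C1CC[C@@H]2[C@](C)(COC(C)=O)[C@H](O)CC[C@@]2(C)[C@@H]1C/C=C1/C(=O)OC[C@H]1O`, gives 2.04 uM in this assay. Compounds 2 and 3 differ in more than one place, and the difference between their cores is not broken down here.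

Compound 3 and compound 1 are a matched pair: the change from compound 3 to compound 1 is acetyl in place of hydrogen on an oxygen on a saturated carbon. That change produced a 5.0-fold lower number from compound 3 to compound 1 (0.70 log units; beyond the scatter).

Compound 4, with the structure `C=C1CC[C@@H]2[C@](C)(COC(C)=O)[C@H](O)CC[C@@]2(C)[C@@H]1C/C=C1/C(=O)OC[C@H]1OC(C)=O`, has not yet been measured. The change from compound 2 to compound 4 is acetyl in place of hydrogen on an oxygen on a saturated carbon. This is the same change as the one from compound 3 to compound 1, since both sit on an oxygen on a saturated carbon whose other neighbours are a saturated ring carbon, and it is the only such change made twice among these compounds.

Because the earlier change gave a 5.0-fold lower number from compound 3 to compound 1 (0.70 log units; beyond the scatter), a step of similar size is expected from compound 2 to compound 4, that is a 4.1-fold lower number from compound 2 to compound 4 (0.61 log units; beyond the scatter), although the two pairs rest on cores that differ elsewhere. Compound 4 is therefore estimated to give 0.5 uM in this assay, with a range from 0.2 uM to 1.5 uM.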

Compound 4, concentration for half-maximal effect: 1.62 uM
Compound 4: the middle estimate sits 3.2-fold (0.51 log units) below what was measured; the whole stated range lies below it.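

In this assay, putting acetyl in place of hydrogen on this oxygen gives a 1.3-fold lower number from compound 2 to compound 4 (0.10 log units; within the scatter) and no clear shift, so the change did not carry over from one core to the other at its earlier size. The same change therefore cannot be treated as a fixed increment in this series, as its effect depends on the core that carries it: the same change on two cores in this assay, a 5.0-fold lower number (0.70 log units; beyond the scatter) from compound 3 to compound 1 and a 1.3-fold lower number (0.10 log units; within the scatter) from compound 2 to compound 4, 4.0-fold (0.60 log units) apart, beyond the scatter of two such steps. This does not show which feature of the cores is responsible, as the two cores differ in more than one place and these differences are not separated by any matched pair here, and two pairs are too few to give a rule for the wider series.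

Going by these compounds, what remains open is whether a group other than acetyl on the same oxygen, such as a longer chain like butyryl or an acyl group carrying an amine, would give a step that holds across both cores. On these data alone, it is also open whether the acetyl step on further cores would resemble the larger step or the smaller one.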